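Arylamino series: 4-propylphenyl to 2-ethoxyphenyl

The source may hold more compounds than are shown below. What is called first, only, known or untested is meant among the compounds shown, and "the series" means these compounds.

- Compound 1 `COc1ccc(NC2=CC(=O)c3c(nc4n3[C@H]3OC[C@@H](O)[C@H]3OC4)C2=O)cc1`: > 8000 nM (a limit)
- Compound 2 `CCCc1ccc(NC2=CC(=O)c3c(nc4n3[C@H]3OC[C@@H](O)[C@H]3OC4)C2=O)cc1`: 6030 nM

For the measured compounds named here, in a functional assay on HeLa cells (Homo sapiens) for inhibition, read by sulforhodamine B assay (on this read-out higher numbers stand for weaker inhibition and lower numbers for stronger inhibition), compound 2 gives 6030 nM, the only actual number so far. Compound 1 gives > 8000 nM, which is a limit of the assay and not a number.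

Next in line is compound 3 `CCOc1ccccc1NC1=CC(=O)c2c(nc3n2[C@H]2OC[C@@H](O)[C@H]2OC3)C1=O`, with the change (2-ethoxyphenyl in place of 4-propylphenyl on an amine nitrogen), in words 2-ethoxyphenyl in place of 4-propylphenyl on an amine nitrogen.

Going by the values given here, only one measured step bears on this: an at least 1.3-fold lower number from compound 1 to compound 2 (0.12 log units; that floor lies within the scatter). That step puts propyl in place of methoxy, whereas compound 3 goes the other way, from a propyl-bearing group to an ethoxy-bearing one. A step to a slightly higher number, or none beyond the scatter, is therefore expected in this assay, though this rests on a single step with an open end. The expected step is a 1.2-fold higher number from compound 2 to compound 3 (0.09 log units; within the scatter). Compound 3 is estimated at 7500 nM, with an expected range of 3000 nM to 18000 nM. A report as a limit alone would not be surprising.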

Compound 3, half-maximal inhibitory concentration: 8300 nM
For compound 3 the middle estimate is 1.1-fold (0.04 log units) below the measured one; low and high end bracket the measured number.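

In this assay, the exchange on the amine nitrogen gives a 1.4-fold higher number from compound 2 to compound 3 (0.14 log units; within the scatter), so 2-ethoxyphenyl and 4-propylphenyl are not separated at this position, although the step replaces an all-carbon substituent with an oxygen-bearing one and changes where the substituent sits on the phenyl ring. Compound 1 stands at > 8000 nM, which is a limit of the assay and not a number, and the step from it to compound 3 cannot be read, so the comparison of 2-ethoxyphenyl with 4-methoxyphenyl yields nothing. Compound 3 does add a second actual number to the series, yet both numbers lie close to the top of the range that can be read here, which leaves little room to see a further loss at this position: the limit of > 8000 nM in this assay, at which 1 of the 3 values shown sits.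

Going by these compounds, it remains open whether 4-ethoxyphenyl would separate the effect of the ethoxy group from that of its place on the ring. On these data alone, it also remains open whether an amine, a carboxylic acid or a longer chain on the phenyl ring would move the number beyond the scatter in this assay.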